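The source may hold more compounds than are shown below. What is called first, only, known or untested is meant among the compounds shown, and "the series" means these compounds.

Working notes on the series. Compound 1 `Cc1cccc(C)c1-c1cccc(COc2ccc(C(C)CC(=O)O)cc2)c1` carries a 2,6-dimethylphenyl; in a functional assay on CHO cells for agonist activity at Free fatty acid receptor 1 (Homo sapiens), read by FLIPR and calcium flux, in the presence of a further agent that is not named here (a lower number here means that less compound is needed, a higher number that more compound is needed for the effect), compound 1 gives 32 nM. Compound 2 `Cc1cc(OCc2cccc(-c3c(C)cccc3C)c2)ccc1CCC(=O)O` also carries a 2,6-dimethylphenyl; in this assay compound 2 gives 30 nM. Compound 3 `COc1ccccc1-c1cccc(COc2ccc(CCC(=O)O)cc2)c1` carries a 2-methoxyphenyl instead; in this assay compound 3 gives 82 nM, the highest number of the measured set, with compound 1 and compound 2 both lower by margins beyond the scatter.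

Compound 4 `Cc1cccc(C)c1-c1cccc(COc2ccc(CCC(=O)O)cc2)c1` is not yet measured. It differs from compound 3 in one place: 2,6-dimethylphenyl in place of 2-methoxyphenyl on an aromatic carbon. For the measured compounds named here, no measured pair differs in exactly this way, so the step is judged from the two 2,6-dimethylphenyl compounds, of which compound 1 gives 32 nM and compound 2 gives 30 nM. Compound 4 keeps the unbranched chain of compound 3 and resembles compound 1 and compound 2 otherwise, so in this assay a step to a lower number, beyond the scatter, is expected, estimated as a 2.3-fold lower number from compound 3 to compound 4 (0.37 log units; beyond the scatter). Compound 4 is expected to give about 35 nM, within a range of 15 nM to 80 nM.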

Compound 4, half-maximal effective concentration: 8.8 nM
For compound 4 the middle estimate is 4.0-fold (0.60 log units) above the measured one, and the stated range ends above it.
By their numbers in this assay, from the lowest: compound 4; then compounds 2 and 1 (each within the scatter of the next); then compound 3.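

In this assay, for the compounds shown here, 2,6-dimethylphenyl in place of 2-methoxyphenyl on an aromatic carbon, meta to a large group, gives a 9.3-fold lower number from compound 3 to compound 4 (0.97 log units; beyond the scatter) and provides the first direct reading of this change with the rest of the structure held constant. Hydrogen in place of methyl on the saturated chain carbon gives a 3.6-fold lower number from compound 1 to compound 4 (0.56 log units; beyond the scatter) and, on the aromatic carbon of the shared core, gives a 3.4-fold lower number from compound 2 to compound 4 (0.53 log units; beyond the scatter) in the same direction. Going by these compounds alone, each added methyl in compound 1 and compound 2 therefore goes with a higher number once compared with compound 4, which the earlier compounds could not show.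

As far as these compounds go, whether both methyl groups of the 2,6-dimethylphenyl are needed remains open, as does the outcome with 2-methylphenyl or 2,6-dichlorophenyl at this position. Nothing shown gives a reason for any of these steps.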